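Adding trifluoromethyl to a compound at the assay limit

The compounds below may be only part of what the source reports. "The series", "measured", "known", "first", "only" and "open" are said of these compounds alone.

Compound 1 (`C=C[C@@](C)(/C=C/c1ccc(Nc2ccccc2)cc1)CCC=C(C)C`) offers no number to start from. In a functional assay on Raji cells (Homo sapiens) for cytotoxicity, with a stated time of 72 h (on this read-out lower numbers stand for an effect already at smaller amounts and higher numbers for an effect only at larger amounts of compound), compound 1 gives > 26000 nM, which is a limit. Compound 2 (`C=C[C@@](C)(/C=C/c1ccc(Nc2c(F)cc(F)cc2F)cc1)CCC=C(C)C`) gives > 26000 nM in this assay, again a limit. Among the measured compounds shown here, the only measured step bearing on the change is a step that the two limits leave unreadable from compound 1 to compound 2, and it has no readable size. It also concerns a different substitution, so it offers only weak guidance.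

Compound 3 (`C=C[C@@](C)(/C=C/c1ccc(Nc2cccc(C(F)(F)F)c2)cc1)CCC=C(C)C`) differs from compound 1 by trifluoromethyl in place of hydrogen on an aromatic carbon. Since compound 1 and compound 2 both rest at the limit of > 26000 nM in this assay, at which 2 of the 2 values shown sit, no step beyond the scatter is expected, and a reading at the limit is the likeliest outcome. The estimated change is a step that the limit leaves unreadable from compound 1 to compound 3. Compound 3 is expected at about 30000 nM, with an estimated range from 12000 nM to 60000 nM.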

Compound 3, half-maximal effective concentration: > 26000 nM
Compound 3 was reported as a limit; the forecaster's own chance of this, stated with the estimate: 80%; the middle value does not contradict the limit.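

Among the compounds shown here, compound 1 and compound 3 both stand at a limit in this assay, so no step between them can be read. The compounds shown leave open whether any change to the shared core would give a readable value, since all of them sit at one limit: the limit of > 26000 nM in this assay, at which 3 of the 3 values shown sit.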